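The source may hold more compounds than are shown below. What is called first, only, known or untested is meant among the compounds shown, and "the series" means these compounds.

Measured so far in a functional assay on the whole organism (strain Swiss) with Mus musculus as the target, in the maximal electroshock model, with a stated time of 0.25 h, at a dose of 100 mg/kg by the intraperitoneal route; on this read-out lower numbers stand for a weaker effect and higher numbers for a stronger effect at the one dose given:
compound 1 `CC(C(=O)N1CCN(c2cccc(F)c2)CC1)N1C(=O)CCC1=O` gives 75%
compound 2 `Cc1cccc(N2CCN(C(=O)C(C)N3C(=O)CCC3=O)CC2)c1` gives 0%

Compound 2 stands lowest of the two numbers; its nearest neighbour is compound 1, and the step of a number 75 percentage points lower from compound 1 to compound 2 (beyond the scatter) is beyond the scatter. Compound 3 `CC(C(=O)N1CCN(c2cccc(C(F)(F)F)c2)CC1)N1C(=O)CCC1=O` has not been measured. It differs from compound 2 in one place: trifluoromethyl in place of methyl on an aromatic carbon. Among the measured compounds shown here, the only measured step, a number 75 percentage points lower from compound 1 to compound 2 (beyond the scatter), concerns methyl in place of fluoro on an aromatic carbon, so trifluoromethyl has no measured precedent, and the data do not settle the direction of the coming step. Compound 2 already sits at the bottom of the read-out; a step down cannot appear, and a rise as far as compound 1 is possible but not shown. The expected step of a number 35 percentage points higher from compound 2 to compound 3 (beyond the scatter) is upward, with wide uncertainty. Compound 3 is estimated at 35%, within 0% to 75%.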

Compound 3, a percentage reported as activity, at one dose (the size of the read-out at that dose, not a potency): 50%
Compound 3: middle estimate off by 15 percentage points, on the low side; low and high end bracket the measured number.
By their numbers in this assay, from the lowest: compound 2; then compound 3; then compound 1.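

In this assay, the group on this aromatic carbon now has three measured states, and trifluoromethyl in place of methyl gives a number 50 percentage points higher from compound 2 to compound 3 (beyond the scatter), so the loss seen with methyl does not extend to every carbon-based group at this place. Trifluoromethyl in place of fluoro gives a number 25 percentage points lower from compound 1 to compound 3 (beyond the scatter) and thus recovers only part of the read-out, leaving fluoro as the best of the three groups at this place. No measured evidence bears on why either step takes the size it does.

The compounds shown leave open how chloro, methoxy or an amine on the same aromatic carbon would read against these three groups. They also leave open whether the order of the three holds at other doses or times, as a single-dose read-out gives no potency.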